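Guanidine series: pentan-3-yl to isopropyl on the acyl group

The source may report more compounds than this note shows. Statements on the series, on what has been measured and on what is new or still open speak of the compounds shown alone.

Working notes on two acylguanidines measured in an in vitro ADME assay on microsomes from liver (Homo sapiens) for metabolic stability (on this read-out higher numbers stand for a longer-lived compound and lower numbers for a shorter-lived compound), and one still to be run. Compound 1 `CCC(CC)C(=O)N/C(=N/C1=NC(=O)C(=O)N1C(C)C)Nc1ccc(Cl)c(Cl)c1` carries the dichlorophenyl on a guanidine nitrogen and the isopropyl on the ring; in this assay compound 1 gives > 1 h, which is a limit of the assay rather than a number, as the limit of > 1 h in this assay, at which 1 of the 2 values shown sits, records. Compound 2 `CCC(CC)C(=O)N/C(=N\C1=NC(=O)C(=O)N1c1ccc(Cl)c(Cl)c1)NC(C)C` has the two groups exchanged, the dichlorophenyl now on the ring and the isopropyl on the guanidine nitrogen. In this assay compound 2 gives < 0.167 h, again a limit rather than a number, as the limit of < 0.167 h in this assay, at which 1 of the 2 values shown sits, records. Within the data shown here, no step between these two compounds is worked out here; their values simply sit at opposite limits of this assay.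

Compound 3 `CC(C)N/C(=N/C1=NC(=O)C(=O)N1c1ccc(Cl)c(Cl)c1)NC(=O)C(C)C` keeps the arrangement of compound 2 and differs only in isopropyl in place of pentan-3-yl on a carbonyl carbon. Among the measured compounds shown here, no measured step covers this change, and nothing in the data gives it a direction, so the expectation from compound 2 to compound 3 is a step that the limit leaves unreadable from compound 2 to compound 3, that is, no movement beyond the scatter. Compound 3 is therefore estimated at 0.15 h in this assay, within a range of 0.05 h to 0.5 h, and most likely again reported only as a limit.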

Compound 3, half-life: < 0.167 h
Compound 3: no number, only a limit (the forecaster's own chance of this, stated with the estimate: 60%); the middle value does not contradict the limit.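

In this assay compound 3 gives < 0.167 h as a limit of the assay and not a number. Among these compounds, compound 2 sits at the same limit, so no step between compound 2 and compound 3 can be read: the limit of < 0.167 h in this assay, at which 2 of the 3 values shown sit. The compounds shown leave open whether isopropyl in place of pentan-3-yl on a carbonyl carbon alters the half-life at all.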